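The compounds below may be only part of what the source reports. "The series", "measured", "known", "first", "only" and "open" are said of these compounds alone.

Results in a functional assay on MC-38 cells (Mus musculus) for antiproliferative activity, read by CCK-8 assay, with a stated time of 48 h (on this read-out lower numbers stand for stronger inhibition and higher numbers for weaker inhibition), for three compounds on the shared core:

Compound 1 `COc1ccc(/C=C\c2cc(OC)c(OC)c(OC)c2)cc1OCc1ccc(CN[C@H](C(=O)O)[C@H](C)O)cc1` gives > 10000 nM as a limit of the assay, not a number.
Compound 2 `COc1ccc(/C=C\c2cc(OC)c(OC)c(OC)c2)cc1OCc1ccc(CO)cc1` gives 5700 nM as a measured number.
Compound 3 `COc1ccc(/C=C\c2cc(OC)c(OC)c(OC)c2)cc1OCc1ccc(CN2CC[C@@H](O)C2)cc1` gives 6900 nM as a measured number.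

Compound 3 cannot be told apart from compound 2 (a 1.2-fold higher number from compound 2 to compound 3 (0.08 log units; within the scatter)). Compound 4 `COc1ccc(/C=C\c2cc(OC)c(OC)c(OC)c2)cc1OCc1ccc(CN2CCCCC2C(=O)NCCN)cc1` changes the group on the saturated chain carbon bound to an aromatic carbon (2-((2-aminoethyl)carbamoyl)piperidin-1-yl in place of 3-hydroxypyrrolidin-1-yl on a saturated chain carbon bound to an aromatic carbon). Exchanges at this place have so far shown no step beyond the scatter, and compound 1 offers only a floor (an at least 1.4-fold lower number from compound 1 to compound 3 (0.16 log units; that floor lies within the scatter)). So in this assay no step beyond the scatter is expected (a 1.4-fold lower number from compound 3 to compound 4 (0.14 log units; within the scatter)). The estimate for compound 4 is 5000 nM with an expected range from 1500 nM to 11000 nM around it.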

Compound 4, half-maximal inhibitory concentration: > 10000 nM
Compound 4 was reported as a limit; the forecaster's own chance of this, stated with the estimate: 20%; middle value at least 2.0-fold (0.30 log units) from the limit.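

In this assay compound 4 gives only a limit, not a number, and it is the second compound at this place to do so: the limit of > 10000 nM in this assay, at which 2 of the 4 values shown sit.

Its steps are an at least 1.4-fold higher number from compound 3 to compound 4 (0.16 log units; that floor lies within the scatter) and an at least 1.7-fold higher number from compound 2 to compound 4 (0.24 log units; that floor lies within the scatter), so both floors stay inside the scatter and any real loss remains unproven. The step between the two limits cannot be read.

Going by these compounds, how far compound 4 lies past its limit stays open. So does what a simple amine or a carboxylic acid placed directly on this saturated chain carbon would give.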